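Trifluoromethylphenyl replaces chlorophenyl on a shared core

A few compounds are considered here, and "the series" means these few. Any claim that something is new, unique, unknown or untested is made for them only; others in the source may bear on it.

Measured compounds:
compound 1 `C=CCn1c(=O)/c(=C\c2cc(F)ccc2C)[nH]c(=O)/c1=C\c1ccccc1OC` – 3100 nM
compound 2 `C=CCn1c(=O)/c(=C\c2ccccc2OC)[nH]c(=O)/c1=C\c1ccccc1OC` – 41100 nM
compound 3 `C=CCn1c(=O)/c(=C\c2cccc(Cl)c2)[nH]c(=O)/c1=C\c1ccccc1OC` – 5200 nM

Three compounds share one core and differ only in the aryl group on a double-bonded chain carbon bound to an aromatic carbon. In a functional assay on MCF7 cells (Homo sapiens) for cytotoxicity, read by CCK-8 assay, with a stated time of 72 h (on this read-out higher numbers stand for weaker inhibition and lower numbers for stronger inhibition), compound 1 gives 3100 nM, compound 2 gives 41100 nM, and compound 3 gives 5200 nM. Compound 3 holds the second highest number of the three: one of its steps is a 1.7-fold higher number from compound 1 to compound 3 (0.22 log units; within the scatter), while the other is a 7.9-fold lower number from compound 2 to compound 3 (0.90 log units; beyond the scatter).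

Compound 4 `C=CCn1c(=O)/c(=C\c2ccccc2C(F)(F)F)[nH]c(=O)/c1=C\c1ccccc1OC` has not yet been tested. It differs from compound 3 in one place: 2-(trifluoromethyl)phenyl in place of 3-chlorophenyl on a double-bonded chain carbon bound to an aromatic carbon. Among the measured compounds shown here, no measured step exchanges a 3-chlorophenyl for a 2-(trifluoromethyl)phenyl, so the expectation rests on the spread seen so far. For the measured compounds named here, the single change that moved beyond the scatter, a 7.9-fold lower number from compound 2 to compound 3 (0.90 log units; beyond the scatter), involved a 2-methoxyphenyl, not the group entering here, and the step of a 1.7-fold higher number from compound 1 to compound 3 (0.22 log units; within the scatter) stayed within the scatter. In this assay compound 4 is therefore expected to sit near compound 3, with a step of about a 1.2-fold higher number from compound 3 to compound 4 (0.06 log units; within the scatter), and the estimate for compound 4 is 6000 nM, within a range from 1500 nM to 25000 nM.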

Compound 4, half-maximal inhibitory concentration: 6500 nM
The estimate for compound 4 lay 1.1-fold (0.03 log units) below the measured number; measured number inside the range.
By their numbers in this assay, from the lowest: compounds 1, 3 and 4 (each within the scatter of the next, the first and the last beyond it); then compound 2.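

In this assay, this place accepts 2-(trifluoromethyl)phenyl, with 10 heavy atoms, in place of 3-chlorophenyl, with 7, without a change beyond the scatter: a 1.3-fold higher number from compound 3 to compound 4 (0.10 log units; within the scatter). Trifluoromethyl in place of methoxy on an aromatic carbon gives a 6.3-fold lower number from compound 2 to compound 4 (0.80 log units; beyond the scatter), so compound 2, with its 2-methoxyphenyl group, now stands apart from all three other aryl compounds. The set also gains a second step beyond the scatter among those three, a 2.1-fold higher number from compound 1 to compound 4 (0.32 log units; beyond the scatter), although compound 3 remains within the scatter of both compound 1 and compound 4. Nothing shown here accounts for these differences.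

The compounds shown leave open how an aryl group carrying an amine or a carboxylic acid would fare at this place. They also leave open whether a longer chain could replace the aryl group.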